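The source may report more compounds than this note shows. Statements on the series, on what has been measured and on what is new or still open speak of the compounds shown alone.

For the measured compounds named here, compound 1 `CCC(=O)Nc1sc2c(c1C#N)CCCC2` is the only compound here that yields an actual number: in a functional assay on RKE cells for antagonist activity at Vasoactive intestinal polypeptide receptor 1 (Rattus norvegicus), read by HTRF and cAMP accumulation, with stated times of 10 min and 30 min (a higher number here means a weaker inhibitor, a lower number a stronger inhibitor), compound 1 gives 12000 nM. Compound 2 `CC(C)c1cc(C(C)(C)C)cc(-c2cccc(C(F)(F)F)c2)c1CO` returns only a limit of the assay, and in this assay compound 2 gives > 50000 nM. Compound 3 `CC(C)c1cc(C(C)(C)C)cc(-c2cccc(C#N)c2)c1CO` likewise returns a limit, so that in this assay compound 3 gives > 50000 nM. The change of cyano in place of trifluoromethyl on an aromatic carbon thus gives a step that the two limits leave unreadable from compound 2 to compound 3, because both values sit at the limit of > 50000 nM in this assay, at which 2 of the 3 values shown sit. Compound 4 `N#Cc1c(NC(=O)C2CCC2)sc2c1CCCC2` differs from compound 1 by cyclobutyl in place of ethyl on a carbonyl carbon. Going by the values given here, no measured step touches this carbonyl position, so nothing measured bears on it, and no shift beyond the usual scatter is expected. For compound 4 the expected step is a 1.2-fold lower number from compound 1 to compound 4 (0.08 log units; within the scatter). Compound 4 is estimated at 10000 nM, within a range from 3000 nM to 40000 nM.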

Compound 4, half-maximal inhibitory concentration: 1800 nM
For compound 4 the middle estimate is 5.6-fold (0.74 log units) above the measured one; measured number below the stated range.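

In this assay, the carbonyl position proves open to change: cyclobutyl in place of ethyl on a carbonyl carbon gives a 6.7-fold lower number from compound 1 to compound 4 (0.82 log units; beyond the scatter), a shift beyond the usual scatter. This is the only readable step among the compounds shown, as the step between compound 2 and compound 3 cannot be read. Nothing shown accounts for this gain.

The compounds shown leave open whether the gain follows the ring itself or the added carbons. They also leave open how a butyl chain, a cyclopentyl ring or an amine would read on this carbonyl carbon.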